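From methyl to sec-butyl: the step to compound 4

The source may report more compounds than this note shows. Statements on the series, on what has been measured and on what is new or still open speak of the compounds shown alone.

Values so far in a physicochemical assay for solubility (on this read-out lower numbers stand for lower solubility and higher numbers for higher solubility), are these
- compound 1 `Cc1nc(C)c(COC(=O)COc2ccc(-c3cc(=O)c4c(O)c(O)c(O)cc4o3)cc2)nc1C` gives 30.6 ug/mL in this series
- compound 2 `Cc1nc(C)c(C(=O)N[C@H](CC(C)C)C(=O)Oc2ccc(-c3cc(=O)c4c(O)c(O)c(O)cc4o3)cc2)nc1C` gives 26 ug/mL in this series
- compound 3 `Cc1nc(C)c(COC(=O)N[C@H](C)C(=O)Oc2ccc(-c3cc(=O)c4c(O)c(O)c(O)cc4o3)cc2)nc1C` gives 799 ug/mL in this series

Compound 3 stands highest of the three at 799 ug/mL on this scale, and its gap to each of the other two compounds lies beyond the scatter. Compound 4 `CC[C@H](C)[C@@H](NC(=O)OCc1nc(C)c(C)nc1C)C(=O)Oc1ccc(-c2cc(=O)c3c(O)c(O)c(O)cc3o2)cc1` has not yet been measured. Within the data shown here, it carries sec-butyl in place of methyl on a saturated chain carbon bound to an amide-type nitrogen and a carbonyl carbon as its one change from compound 3.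

Among the measured compounds shown here, no measured pair isolates a change of this kind, so the expectation remains loose. The values show only that this series can fall far below compound 3, with compound 2 at 26 ug/mL as one example. A downward move beyond the scatter is expected, with the estimated size a 5.0-fold lower number from compound 3 to compound 4 (0.70 log units; beyond the scatter) in this assay as the working figure. For compound 4 the estimated value is 160 ug/mL with 30 ug/mL to 650 ug/mL as its expected range.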

Compound 4, solubility: 234 ug/mL
Beside the measured number, compound 4's estimate is 1.5-fold (0.17 log units) below it; measured number inside the range.
By their numbers in this assay, from the lowest: compounds 2 and 1 (each within the scatter of the next); then compound 4; then compound 3.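

Among these compounds, compound 4 and compound 3 form the first pair that differs in one place, so the effect of a change on a saturated chain carbon bound to an amide-type nitrogen and a carbonyl carbon can now be read directly. In this assay, sec-butyl in place of methyl gives a 3.4-fold lower number from compound 3 to compound 4 (0.53 log units; beyond the scatter) as a modest downward step, and compound 4 still reads 234 ug/mL on this scale. Neither group carries a ring or a net charge, and nothing shown here accounts for the step.

This single step cannot separate the effect of chain length from that of branching or the defined stereocentre that sec-butyl adds. As far as these compounds go, how an unbranched butyl chain, an amine or a carboxylic acid would read at this place remains open.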